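A few compounds are considered here, and "the series" means these few. Any claim that something is new, unique, unknown or untested is made for them only; others in the source may bear on it.

Measured in a functional assay on DU-145 cells (Homo sapiens) for inhibition, read by trypan blue exclusion, with a stated time of 96 h; on this read-out higher numbers stand for weaker inhibition of growth and lower numbers for stronger inhibition of growth:
- Compound 1 `Cc1ccc(S/C(=C/c2ccc(Cl)c(Cl)c2)C(=O)c2ccc(Br)cc2)cc1`: 50000 nM
- Compound 2 `Cc1ccc(S/C(=C/c2ccc(Cl)cc2)C(=O)c2ccc(Br)cc2)cc1`: 10000 nM
- Compound 3 `Cc1ccc(S/C(=C/c2c(O)cc(O)cc2O)C(=O)c2ccc(Br)cc2)cc1`: > 100000 nM (a limit, not a number)

Compound 3 has no exact value, only a limit: the limit of > 100000 nM in this assay, at which 1 of the 3 values shown sits.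

Compound 4 `Cc1ccc(S/C(=C/c2ccc(F)cc2F)C(=O)c2ccc(Br)cc2)cc1` keeps the shared core and changes one group: 2,4-difluorophenyl in place of 2,4,6-trihydroxyphenyl on a double-bonded chain carbon bound to a double-bonded chain carbon. Going by the values given here, no compound with a 2,4-difluorophenyl group has been measured yet, so the closest guides are the two compounds with chloro-bearing rings in that place.

Going the opposite way, the measured steps are an at least 10-fold higher number from compound 2 to compound 3 (1.00 log units; beyond the scatter) and an at least 2.0-fold higher number from compound 1 to compound 3 (0.30 log units; that floor lies within the scatter). These two rings also differ from each other, with a 5.0-fold lower number from compound 1 to compound 2 (0.70 log units; beyond the scatter).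

Compound 4 is therefore expected to resemble compound 1 and compound 2 more than compound 3, giving a lower number in this assay. The expected change is an at least 6.6-fold lower number from compound 3 to compound 4 (0.82 log units; beyond the scatter).

The estimated value for compound 4 is 15000 nM, with an expected range of 4000 nM to 60000 nM.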

Compound 4, concentration for 50% growth inhibition: > 100000 nM
Compound 4 ended at the assay's limit (the forecaster's own chance of this, stated with the estimate: 10%); middle value at least 6.6-fold (0.82 log units) away from the limit.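

In this assay compound 4 gives > 100000 nM, which is a limit of the assay and not a number. The earlier limit belonged to a ring with 3 hydrogen-bond donors, whereas this ring has 0, so at this place a ring without donors can also fall short of the 4-chlorophenyl group, with an at least 10-fold higher number from compound 2 to compound 4 (1.00 log units; beyond the scatter), while the comparison with the 3,4-dichlorophenyl group gives only an at least 2.0-fold higher number from compound 1 to compound 4 (0.30 log units; that floor lies within the scatter). The step from compound 3 to compound 4 cannot be read, and the two rings cannot be put in order, as both stop at the same point: the limit of > 100000 nM in this assay, at which 2 of the 4 values shown sit.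

The compounds shown leave open whether this outcome goes with fluorine itself or with the particular arrangement of the 2,4-difluorophenyl group. A 4-fluorophenyl group or an unsubstituted phenyl group at this place would help to separate those two possibilities.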